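The source may report more compounds than this note shows. Statements on the series, on what has been measured and on what is new or still open speak of the compounds shown alone.

In an ADME assay on HELF cells (Homo sapiens) for cytotoxicity, with a stated time of 3 days (on this read-out lower numbers stand for higher toxicity in this test and higher numbers for lower toxicity in this test), compound 1, whose structure is `C[C@H](NC(=O)[C@@]1(Cc2ccccc2)CCN1C(=O)OCc1ccccc1)C(=O)NCc1ccccc1`, gives 42000 nM. Its stereoisomer compound 2, `C[C@H](NC(=O)[C@]1(Cc2ccccc2)CCN1C(=O)OCc1ccccc1)C(=O)NCc1ccccc1`, gives 42000 nM in this assay, so the step of no change at the digits printed from compound 1 to compound 2 (within the scatter) leaves the read-out where it was; the two compounds share every atom and bond, and the fact that compounds 1 and 2 differ only in the configuration as drawn is the only way they differ. Among the compounds with values here, compound 1 therefore stands level with its one measured neighbour, and nothing among the measured compounds shows a shift beyond the scatter in either direction.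

The next compound, compound 3, has the structure `CC(C)[C@H](NC(=O)[C@@]1(Cc2ccccc2)CCN1C(=O)OCc1ccccc1)C(N)=O`. Its change from compound 1 is 1-carbamoyl-2-methylpropyl in place of 1-(benzylcarbamoyl)ethyl on an amide-type nitrogen. Within the data shown here, the only measured step concerns a configuration alone and not a replacement of one group by another, so it bears on this change only weakly; it shows that the read-out of this series can sit unmoved across a small structural edit, and no measured step points to a move in either direction. The estimated step of a 1.2-fold higher number from compound 1 to compound 3 (0.08 log units; within the scatter) is therefore expected to stay within the scatter. Compound 3 is expected to give about 50000 nM, within a range from 20000 nM to 120000 nM.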

Compound 3, half-maximal cytotoxic concentration: 85000 nM
Beside the measured number, compound 3's estimate is 1.7-fold (0.23 log units) below it; measured number inside the range.
By their numbers in this assay, from the lowest: compounds 1 and 2 (each within the scatter of the next); then compound 3.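

Within the data shown here, on the amide-type nitrogen, 1-carbamoyl-2-methylpropyl in place of 1-(benzylcarbamoyl)ethyl gives the first step in this assay that lies beyond the scatter: a 2.0-fold higher number from compound 1 to compound 3 (0.31 log units; beyond the scatter), a modest move towards lower toxicity in this test. This position can therefore shift the read-out, whereas the change of configuration at the saturated ring carbon between the first two compounds left it unmoved. Among these compounds, the entering group has fewer heavy atoms and no ring, with the same count of hydrogen-bond donors and acceptors, but the one configuration comparison available says nothing about the cause of this step.

Because the replacement changes both ends of the group at once, these compounds cannot show whether the loss of the benzyl group or the gain of the branched chain matters, and 1-carbamoylethyl or 1-(benzylcarbamoyl)-2-methylpropyl on the same nitrogen would separate the two. As far as these compounds go, it also remains open whether a carboxylic acid in place of the terminal carbamoyl would move the read-out, and whether the ring-carbon configuration stays without effect when 1-carbamoyl-2-methylpropyl is present.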